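A few compounds are considered here, and "the series" means these few. Any claim that something is new, unique, unknown or untested is made for them only; others in the source may bear on it.

Compound 1 `Cc1cc(C)cc(S(=O)(=O)c2c(C(=O)NC(c3ccc(Cl)cc3)C3CC3)[nH]c3ccc(Cl)cc23)c1`: in an ADME assay on MT4 cells (Homo sapiens) for cytotoxicity, read by MTT assay (on this read-out lower numbers stand for higher toxicity in this test and higher numbers for lower toxicity in this test), compound 1 reaches only the limit > 47300 nM.
Compound 2 `Cc1cc(C)cc(S(=O)(=O)c2c(C(=O)NCC(=O)NCc3ccncc3)[nH]c3ccc(Cl)cc23)c1`: in this assay compound 2 reaches only the limit > 48900 nM.
Compound 3 `Cc1cc(C)cc(S(=O)(=O)c2c(C(=O)NC(C)c3cc(F)cc(F)c3)[nH]c3ccc(Cl)cc23)c1`: in this assay compound 3 reaches only the limit > 49700 nM.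

The three measured compounds share one core and differ only in the group attached to the amide-type nitrogen. Compound 1 stands at a limit of the assay, and no true number is known for it; the same holds for the other two. Compound 4 `Cc1cc(C)cc(S(=O)(=O)c2c(C(=O)NCC(=O)NC(C)c3ccncc3)[nH]c3ccc(Cl)cc23)c1` carries yet another group at that position: a group of 12 heavy atoms (9 carbon, 2 nitrogen, 1 oxygen; one six-membered aromatic ring with 1 hetero atom) in place of a group of 11 heavy atoms (10 carbon, 1 chlorine; one three-membered non-aromatic ring of carbon only, one six-membered aromatic ring of carbon only), on an amide-type nitrogen. The measured steps that bear on this change are a step that the two limits leave unreadable from compound 1 to compound 2 and a step that the two limits leave unreadable from compound 1 to compound 3. Both run from one limit to another, so their size cannot be read, and no change beyond the scatter can be drawn from them because every value sits at a limit of > 47300 nM in this assay, at which 1 of the 3 values shown sits, the limit of > 48900 nM in this assay, at which 1 of the 3 values shown sits (the limit of > 49700 nM in this assay, at which 1 of the 3 values shown sits). For compound 4 the step that the limit leaves unreadable from compound 1 to compound 4 is therefore expected to show nothing beyond the scatter. Compound 4 is estimated at 50000 nM, within 30000 nM to 100000 nM, most likely reported again as a limit.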

Compound 4, half-maximal cytotoxic concentration: 47000 nM
The estimate for compound 4 lay 1.1-fold (0.03 log units) above the measured number; the measured number falls inside the stated range.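

Among the compounds shown here, compound 4 gives the first true number in this assay; the other three values are limits. Methyl in place of hydrogen on a saturated chain carbon bound to an amide-type nitrogen and an aromatic carbon gives an at least 1.0-fold lower number from compound 2 to compound 4 (0.01 log units; that floor lies within the scatter), and exchanging the whole group on the amide-type nitrogen gives an at least 1.0-fold lower number from compound 3 to compound 4 (0.02 log units; that floor lies within the scatter), so neither change is shown to do more than the usual scatter, though the true gaps may be larger. A further exchange of the whole group on the amide-type nitrogen gives a number no higher from compound 1 to compound 4 (the limit leaves the size open) and the size of this step cannot be read, because its starting value is a limit: the limit of > 47300 nM in this assay, at which 1 of the 4 values shown sits.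

As far as these compounds go, the true size of these steps stays open. From the compounds shown here alone, it also stays open how this assay would read with an amine or a carboxylic acid at the end of the chain on the amide-type nitrogen.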